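Phenyl in place of 3-fluorophenyl in the ethyl branch

The source may hold more compounds than are shown below. What is called first, only, known or untested is meant among the compounds shown, and "the series" means these compounds.

Three compounds of a shared core carry numbers in a functional assay on the whole organism (strain Swiss) with Mus musculus as the target, in the maximal electroshock model, with a stated time of 0.25 h, at a dose of 300 mg/kg by the intraperitoneal route; on this read-out lower numbers stand for a weaker effect and higher numbers for a stronger effect at the one dose given. Compound 1 `CC(C(=O)N1CCN(c2ccc(Cl)cc2)CC1)N1C(=O)CCC1=O` gives 100%. Compound 3 `CC(C(=O)N1CCN(c2cccc(F)c2)CC1)N1C(=O)CCC1=O` gives 100%, and the step of no change at the digits printed from compound 1 to compound 3 (within the scatter) shows that this exchange of the aryl group passes without effect beyond the scatter. Compound 2 `CCC(C(=O)N1CCN(c2cccc(F)c2)CC1)N1C(=O)CCC1=O` gives 75%, the lowest of the three numbers; the step of a number 25 percentage points higher from compound 2 to compound 3 (beyond the scatter) lies beyond the scatter and concerns the chain, not the aryl group.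

Compound 4 `CCC(C(=O)N1CCN(c2ccccc2)CC1)N1C(=O)CCC1=O` is not yet measured. Its difference from compound 2 is hydrogen in place of fluoro on an aromatic carbon. Going by the values given here, the only measured step that touches the aryl group, no change at the digits printed from compound 1 to compound 3 (within the scatter), lay within the scatter; no measured step exchanges a fluoro for hydrogen directly. The step of a number 25 percentage points higher from compound 2 to compound 3 (beyond the scatter) fixes only the starting level of compound 2. The expected step of no change at the digits printed from compound 2 to compound 4 (within the scatter) is therefore none beyond the scatter. Compound 4 is estimated at 75%, with a range from 50% to 100%.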

Compound 4, a percentage reported as activity, at one dose (the size of the read-out at that dose, not a potency): 75%
Estimate against measurement, compound 4: no gap at the digits printed; the measured number falls inside the stated range.
By their numbers in this assay, from the lowest: compounds 2 and 4 (each within the scatter of the next); then compounds 1 and 3 (each within the scatter of the next).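

The exchange of 3-fluorophenyl for phenyl, hydrogen in place of fluoro on an aromatic carbon, can now be read directly: this assay gives no change at the digits printed from compound 2 to compound 4 (within the scatter) for this change. The earlier aryl exchange was read where compound 1 gives 100% and compound 3 gives 100%, which leaves no room for a higher number, whereas this one is read at a level open in both directions, so the fluoro is shown to be dispensable on the chain of compound 2 in this read-out. No measurement on hand bears on why the read-out holds when the fluoro leaves.

From the compounds shown here alone, with one dose and one time, any difference in potency between the two compounds remains open. Also open, going by these compounds, are a methoxy group or a trifluoromethyl group on this aromatic carbon, and a longer chain than that of compound 2.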